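A few compounds are considered here, and "the series" means these few. Any claim that something is new, unique, unknown or untested is made for them only; others in the source may bear on it.

Measured in an ADME assay on microsomes from liver (Homo sapiens) for metabolic stability, read by LC-MS, with a stated time of 10 min; a lower number here means that less of the compound is left, a higher number that more of the compound is left:
- compound 1 `CN(C[C@H]1Cc2c(cccc2N2CCNC(C)(C)C2)CN1)[C@H]1CCCc2cccnc21`: 100%
- compound 2 `CCCN(C[C@H]1Cc2c(cccc2N2CCNCC2)CN1)[C@H]1CCCc2cccnc21`: 100%

Compound 1 gives 100% and compound 2 gives 100%, so the two stand level within the scatter. Among the compounds with values here, the two compounds differ in more than one place, and no single-change step between measured compounds is available to calibrate the next one.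

The next compound is compound 3 `CN(C[C@H]1Cc2c(cccc2N2C[C@@H]3C[C@H]2CN3)CN1)[C@H]1CCCc2cccnc21`, which keeps the core of compound 1 and changes one group. The 3,3-dimethylpiperazin-1-yl group on an aromatic carbon gives way to a group with two five-membered non-aromatic rings: a group of 7 heavy atoms (5 carbon, 2 nitrogen; 2 five-membered non-aromatic rings with 1 hetero atom each) in place of a group of 8 heavy atoms (6 carbon, 2 nitrogen; one six-membered non-aromatic ring with 2 hetero atoms), on an aromatic carbon.

In this assay, no change beyond the scatter is expected. The expectation rests only on the two measured compounds, which stay level despite their structural differences. Any shift would be expected to be downward, since compound 1 already reads 100%. The expected size of the change is a number 5 percentage points lower from compound 1 to compound 3 (within the scatter), which lies within the scatter. For compound 3 the estimated value is 95%, with an expected range of 82% to 100%.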

Compound 3, percent of the compound remaining: 100%
Compound 3: the middle estimate sits 5 percentage points below what was measured; the measured number falls inside the stated range.
By their numbers in this assay, from the lowest: compounds 1, 2 and 3 (each within the scatter of the next).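

In this assay, within the data shown here, the change on this aromatic carbon, the 3,3-dimethylpiperazin-1-yl group giving way to the group with two five-membered non-aromatic rings and two defined stereocentres, gives no change at the digits printed from compound 1 to compound 3 (within the scatter) and is the first single-change step. It shows that at this position the six-membered ring can be replaced by this two-ring group, with the same counts of hydrogen-bond donors and acceptors and one heavy atom fewer, while compound 3 still gives 100% in this assay. No supporting measurement bears on why the read-out holds, and with compound 3 at the top of the percent scale the step can show only that no loss appears.

On these data alone, whether this position stays level with a different kind of group, such as a morpholin-4-yl ring, an open-chain amine or a carboxylic acid, remains open. Also open, as far as these compounds go, is how the methyl and propyl groups on the side-chain nitrogen compare with the group on the aromatic carbon held constant, since compounds 1 and 2 differ in more than one place.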